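This account rests on a few compounds, and the source may have more. Where it says the series, first, only, none or still open, it means among the compounds named here.

Measured compounds and values:
compound 1 `CC(C)C[C@]1(O)NC(=O)[C@]2(OC(Cc3ccccc3)=CC2=O)[C@H]1O`: > 50000 nM
compound 2 `CC(C)CC(=O)[C@@H]1O[C@@]12C(=O)C=C(Cc1ccccc1)NC2=O`: > 50000 nM

Both results come from an ADME assay on MRC5 cells (Homo sapiens) for cytotoxicity, read by WST assay, with a stated time of 48 h; a lower number here means a stronger inhibitor, a higher number a weaker inhibitor. For compound 1 the value > 50000 nM is a limit of this assay, not a measured number. For compound 2 the value > 50000 nM is likewise a limit. Compound 1 thus stands at the limit of > 50000 nM in this assay, at which 2 of the 2 values shown sit, and the shown data give no ordering of compound 1 against compound 2 beyond that. Compound 3 `CC1=CC(=O)[C@]2(O1)C(=O)N[C@@](O)(CC(C)C)[C@@H]2O` has not yet been measured in this assay. It differs from compound 1 in one place: hydrogen in place of phenyl on a saturated chain carbon bound to a double-bonded ring carbon. For the measured compounds named here, no step between two measured compounds is known here, so the effect of this change cannot be read from a measured pair. Since both shown values sit at the limit, the step is expected to be none beyond the scatter, a step that the limit leaves unreadable from compound 1 to compound 3. Compound 3 is therefore expected to give 80000 nM, within 35000 nM to 250000 nM.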

Compound 3, half-maximal inhibitory concentration: > 50000 nM
Compound 3 ended at the assay's limit; the forecaster's own chance of this, stated with the estimate: 85%; the middle value does not contradict the limit.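

Compound 1 and compound 3 cannot be compared, and no step can be read between them, because both results are limits rather than numbers: the limit of > 50000 nM in this assay, at which 3 of the 3 values shown sit.

The compounds shown leave open whether replacing benzyl with methyl changes anything in this assay, and what actual number any of the three compounds would give.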